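Iodo for pentyl on the aromatic carbon

The source may hold more compounds than are shown below. What is called first, only, known or untested is meant among the compounds shown, and "the series" means these compounds.

The series keeps one core and varies the group on an aromatic carbon. Compound 1 `CC(C)c1ccc(NC(=O)N[C@@H](C)c2ccccc2)cc1`, compound 2 `CCCCc1ccc(NC(=O)N[C@@H](C)c2ccccc2)cc1` and compound 3 `CCCCCc1ccc(NC(=O)N[C@@H](C)c2ccccc2)cc1` have been measured in an ADME assay on the whole organism with Oryza sativa as the target, tested at 0.1 uM; a lower number here means a stronger effect, a higher number a weaker effect of the compound at the concentration tested. Compound 1 gives 98%, compound 2 gives 98% and compound 3 gives 98%. The steps among them, no change at the digits printed from compound 1 to compound 2 (within the scatter), no change at the digits printed from compound 1 to compound 3 (within the scatter) and no change at the digits printed from compound 2 to compound 3 (within the scatter), all lie within the scatter, so compound 3 stands level with compounds 1 and 2 at the digits shown.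

Compound 4 `C[C@H](NC(=O)Nc1ccc(I)cc1)c1ccccc1` is next. It differs from compound 3 as follows: iodo in place of pentyl on an aromatic carbon. Among the measured compounds shown here, none of the measured steps exchanges an alkyl group for iodo; all three only change the alkyl chain and all are flat. They give no direct guide, only the observation that three different groups at this carbon left the read-out unchanged. The step of a number 3 percentage points lower from compound 3 to compound 4 (within the scatter) is therefore expected to stay within the scatter, though the missing matched step widens the range. Compound 4 is estimated at 95%, from 75% to 100%.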

Compound 4, a percentage reported as activity, at one concentration (the size of the read-out at that concentration, not a potency): 99%
For compound 4 the middle estimate is 4 percentage points below the measured one, and the stated range covers the measured number.
By their numbers in this assay, from the lowest: compounds 1, 2, 3 and 4 (each within the scatter of the next).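

Iodo, a single heavy atom and the only non-alkyl group among the compounds shown, gives a number 1 percentage points higher from compound 3 to compound 4 (within the scatter) against pentyl, a number 1 percentage points higher from compound 2 to compound 4 (within the scatter) against butyl and a number 1 percentage points higher from compound 1 to compound 4 (within the scatter) against isopropyl. The flat result in this assay at this aromatic carbon, para to a large group, therefore extends beyond alkyl groups of differing chain length and branching to iodo. No supporting data bear on why the read-out stays level across these groups.

As far as these compounds go, whether any group at this carbon can lower the number remains open, as all four compounds stand level within the scatter. An amine or a carboxylic acid at this carbon, or a change elsewhere on the shared core, would test whether the read-out can move at all.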